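Topoisomerase 1 inhibition: single-concentration notes on a terpyridine-like set

This account rests on a few compounds, and the source may have more. Where it says the series, first, only, none or still open, it means among the compounds named here.

Measured compounds:
- compound 1 `Cc1ccc(-c2cc(-c3ccoc3)cc(-c3ccc(Cl)s3)n2)o1`: 13.2%
- compound 2 `Cc1ccc(-c2cc(-c3ccoc3)cc(-c3ccc(Cl)s3)n2)cc1`: 0%
- compound 3 `Cc1ccsc1-c1cc(-c2ccc(Cl)o2)cc(-c2cccc(Cl)c2)n1`: 5.9%

In an assay on isolated protein for inhibition of DNA topoisomerase 1 (Homo sapiens), with a stated time of 30 min, tested at 100 uM (on this read-out higher numbers stand for more inhibition at the one concentration tested (going by the name of the read-out) and lower numbers for less inhibition), compound 3 gives 5.9%, the second highest of the three numbers; its gap to compound 2 and its gap to compound 1 both lie within the scatter, so no order among the three can be read from these values.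

Compound 4 `Cc1ccsc1-c1cc(-c2ccc(Cl)o2)cc(-c2cccnc2)n1` differs from compound 3 in one place: pyridin-3-yl in place of 3-chlorophenyl on an aromatic carbon.

Among the compounds with values here, the only measured step, a number 13.2 percentage points lower from compound 1 to compound 2 (beyond the scatter), concerns a different change at a different position and is modest in size; no measured step covers the exchange of 3-chlorophenyl for pyridin-3-yl. With nothing directly comparable, no step beyond the scatter is expected in this assay for this change, in either direction.

Compound 4 is therefore estimated to give 6% in this assay, with a range from 0% to 18%. The step this estimate implies, a number 0.1 percentage points higher from compound 3 to compound 4 (within the scatter), is expected to stay within the scatter.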

Compound 4, a percentage reported as inhibition, at one concentration (the size of the read-out at that concentration, not a potency): 21.4%
Compound 4: middle estimate off by 15.4 percentage points, on the low side, outside the stated range (above it).
By their numbers in this assay, from the lowest: compounds 2, 3, 1 and 4 (each within the scatter of the next, the first and the last beyond it).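

The position next to the ring nitrogen, which carries pyridin-3-yl in compound 4, responds to a single exchange: pyridin-3-yl in place of 3-chlorophenyl gives a number 15.5 percentage points higher from compound 3 to compound 4 (beyond the scatter) in this assay and so adds a second step beyond the scatter to the series, at a different position from the first. The exchange removes the chlorine and brings in a ring nitrogen with one hydrogen-bond acceptor, and the pair cannot tell these two parts apart. No available evidence bears on the origin of this step.

Unsubstituted phenyl or pyridin-4-yl at this position would be needed to separate the loss of chlorine from the gain of the ring nitrogen. On these data alone, how an amine or a carboxylic acid on this ring would read out remains open, as does whether the exchange carries over to the core of compound 1.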